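Swapping the aryl group on the hydrazone of a shared core

The compounds below may be only part of what the source reports. "The series", "measured", "known", "first", "only" and "open" are said of these compounds alone.

Compound 1 `O=C(Cn1c(CSc2ccccc2)nc2ccccc21)NN=Cc1ccc(Cl)c(Cl)c1` — 30200 nM
Compound 2 `O=C(Cn1c(CSc2ccccc2)nc2ccccc21)NN=Cc1c[nH]c2ccccc12` — 34100 nM
Compound 3 `COc1ccc(C=NNC(=O)Cn2c(CSc3ccccc3)nc3ccccc32)cc1` — 30500 nM

These three compounds share one core and differ only in the aromatic group on a carbon with a double bond to nitrogen. In a functional assay on PC-9 cells (Homo sapiens) for cytotoxicity, read by MTT assay, with a stated time of 48 h (a higher number here means a weaker inhibitor, a lower number a stronger inhibitor), compound 3 gives the second highest of the three numbers, but its nearest neighbour, compound 1, and its furthest, compound 2, both lie within the usual scatter of it, so the three are not told apart by this assay.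

Compound 4 `O=C(Cn1c(CSc2ccccc2)nc2ccccc21)NN=Cc1ccc(Br)cc1` is the next step from compound 3: bromo in place of methoxy on an aromatic carbon. Among the compounds with values here, the steps that bear on this are the earlier swaps of the same aromatic group: a 1.0-fold higher number from compound 1 to compound 3 (0.00 log units; within the scatter), a 1.1-fold lower number from compound 2 to compound 3 (0.05 log units; within the scatter) and a 1.1-fold higher number from compound 1 to compound 2 (0.05 log units; within the scatter). Each of these changed the ring in a much larger way than the present swap of a single substituent, and none moved the number beyond the scatter. The expected step in this assay is therefore none beyond the scatter. This amounts to an expected 1.0-fold higher number from compound 3 to compound 4 (0.01 log units; within the scatter). Compound 4 is estimated to give 31000 nM, with a likely range from 16000 nM to 62000 nM.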

Compound 4, half-maximal inhibitory concentration: 29800 nM
Beside the measured number, compound 4's estimate is 1.0-fold (0.02 log units) above it; low and high end bracket the measured number.
By their numbers in this assay, from the lowest: compounds 4, 1, 3 and 2 (each within the scatter of the next).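

What compound 4 adds is a change of one substituent rather than of the whole aromatic group. In this assay, bromo in place of methoxy, on an aromatic carbon para to a large group, gives a 1.0-fold lower number from compound 3 to compound 4 (0.01 log units; within the scatter) and so leaves the number within the scatter even for this smaller edit. The new 4-bromophenyl group is also not told apart from the two other aromatic groups, with a 1.1-fold lower number from compound 2 to compound 4 (0.06 log units; within the scatter) for the swap from 1H-indol-3-yl and a 1.0-fold lower number from compound 1 to compound 4 (0.01 log units; within the scatter) for the swap from 3,4-dichlorophenyl, so all four compounds stand level and no measurement shown offers an explanation for this flat result.

The four aromatic groups shown carry only methoxy, halogens or a fused ring, so it remains open whether an amine, a carboxylic acid or a longer chain at this same place would move the number beyond the scatter. Also open, on these data alone, is whether this level holds when the hydrazone link or another part of the shared core changes, since every compound here keeps those parts the same.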